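A few compounds are considered here, and "the series" means these few. Any claim that something is new, unique, unknown or untested is made for them only; others in the source may bear on it.

Measured so far:
- compound 1, `COc1cc(F)ccc1N1C(=O)CSC1c1cccc(C(=O)NCCCCc2ccccc2)c1`: in a functional assay on U2OS cells (Homo sapiens) for inhibition, read by CCK-8 assay, with a stated time of 72 h, tested at 1 uM (on this read-out higher numbers stand for more inhibition at the one concentration tested (going by the name of the read-out) and lower numbers for less inhibition), compound 1 gives 34%
- compound 2, `COc1cccc(OC)c1N1C(=O)CSC1c1cccc(C(=O)NCCCCc2ccccc2)c1`: in this assay compound 2 gives 41%

Within the data shown here, compound 2 stands at the top of these two numbers, but only nominally: the single step between them, a number 7 percentage points higher from compound 1 to compound 2 (within the scatter), does not separate the two compounds beyond the scatter, so nothing here distinguishes a 2,6-dimethoxyphenyl from a 4-fluoro-2-methoxyphenyl on the amide-type nitrogen in the ring.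

Compound 3, `COc1c(F)cccc1N1C(=O)CSC1c1cccc(C(=O)NCCCCc2ccccc2)c1`, is yet to be measured. It differs from compound 2 as follows: 3-fluoro-2-methoxyphenyl in place of 2,6-dimethoxyphenyl on an amide-type nitrogen in a ring.

Among the measured compounds shown here, the only measured step that bears on this exchange is the one from compound 1 to compound 2, which swaps a fluoro-methoxyphenyl for the dimethoxyphenyl and stays within the scatter. Compound 3 returns to a fluoro-methoxyphenyl, with the fluorine at a different ring position. On that basis no step beyond the scatter is expected in this assay; the expected shift is a number 5 percentage points lower from compound 2 to compound 3 (within the scatter).

Compound 3 is therefore estimated at 36%, with a range from 22% to 50%.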

Compound 3, a percentage reported as inhibition, at one concentration (the size of the read-out at that concentration, not a potency): 12%
Estimate against measurement, compound 3: 24 percentage points above; measured number outside the range, below it.
By their numbers in this assay, from the lowest: compound 3; then compounds 1 and 2 (each within the scatter of the next).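

In this assay, this position on the amide-type nitrogen is now shown to respond to the aryl substitution: a number 29 percentage points lower from compound 2 to compound 3 (beyond the scatter), with 3-fluoro-2-methoxyphenyl in place of 2,6-dimethoxyphenyl. The placement of the fluorine also counts, as the change to 3-fluoro-2-methoxyphenyl from 4-fluoro-2-methoxyphenyl gives a number 22 percentage points lower from compound 1 to compound 3 (beyond the scatter), whereas the earlier step between the two other aryl groups stayed within the scatter. Nothing available accounts for the lower number of compound 3.

Every compound shown carries a methoxy group on this aryl ring, so the reading of a hydroxyl group or a plain hydrogen there remains open. Also open, as far as these compounds go, is whether a chlorine or an amine at the fluorine's place would follow the same pattern.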